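The source may hold more compounds than are shown below. What is called first, only, known or untested is meant among the compounds shown, and "the series" means these compounds.

The measured set in an assay for inhibition of 6-phosphofructo-2-kinase/fructose-2,6-bisphosphatase 3 (Homo sapiens), read by ADP-Glo, with a stated time of 2 h; on this read-out higher numbers stand for weaker inhibition and lower numbers for stronger inhibition:
- compound 1 `Cn1ccc2ccc(-c3cc(Nc4ccccc4S(=O)(=O)Nc4cncnc4)cc4nccnc34)cc21` gives 1690 nM
- compound 2 `CNC(=O)c1ccncc1Nc1cc(-c2ccc3ccn(C)c3c2)c2nccnc2c1` gives 83 nM
- compound 3 `CN1CCC(NC(=O)c2ccncc2Nc2cc(-c3ccc4ccn(C)c4c3)c3nccnc3c2)CC1` gives 38 nM

Compound 3 holds the lowest number of the three, and both of its gaps are beyond the scatter: the step of a 2.2-fold lower number from compound 2 to compound 3 (0.34 log units; beyond the scatter) is modest, while compound 1 lies far higher still. So compound 3 is the most potent compound measured here.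

Compound 4 `CN1CC(NC(=O)c2ccncc2Nc2cc(-c3ccc4ccn(C)c4c3)c3nccnc3c2)CCC1=O` is not yet measured. It differs from compound 3 in one place: 1-methyl-6-oxopiperidin-3-yl in place of 1-methylpiperidin-4-yl on an amide-type nitrogen. For the measured compounds named here, the only measured step touching this same amide-type nitrogen is a 2.2-fold lower number from compound 2 to compound 3 (0.34 log units; beyond the scatter), which shows that a substantial change there, from methyl to 1-methylpiperidin-4-yl, moved the number only modestly. The change to compound 4 keeps a six-membered ring with one hetero atom and one acceptor at the same position, so the expected step is small. The expectation is that compound 4 lands near compound 3, with a step of about a 1.6-fold higher number from compound 3 to compound 4 (0.20 log units; within the scatter), giving an estimated 60 nM in this assay, within a range from 25 nM to 150 nM.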

Compound 4, half-maximal inhibitory concentration: 116 nM
Beside the measured number, compound 4's estimate is 1.9-fold (0.29 log units) below it; the measured number falls inside the stated range.
By their numbers in this assay, from the lowest: compound 3; then compounds 2 and 4 (each within the scatter of the next); then compound 1.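

In this assay, the group on this amide-type nitrogen does matter among six-membered rings: 1-methyl-6-oxopiperidin-3-yl in place of 1-methylpiperidin-4-yl gives a 3.1-fold higher number from compound 3 to compound 4 (0.48 log units; beyond the scatter), a modest step. The advantage of compound 3 over the methyl amide, compound 2, is therefore not shared by every such ring, as a 1.4-fold higher number from compound 2 to compound 4 (0.15 log units; within the scatter) places compound 4 and compound 2 within the scatter of each other. Nothing given here explains the difference between the two rings.

The change from compound 3 to compound 4 alters both the carbonyl and the point of attachment of the ring, and the compounds shown do not separate the two. As far as these compounds go, how a 1-methylpiperidin-3-yl group, which would keep that attachment without the carbonyl, or a morpholine ring would read on this nitrogen remains open.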